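A few compounds are considered here, and "the series" means these few. Any claim that something is new, unique, unknown or untested is made for them only; others in the source may bear on it.

Measured compounds and values in a functional assay on BXPC-3 cells (Homo sapiens) for inhibition, read by MTT assay, with a stated time of 7 days; on this read-out lower numbers stand for stronger inhibition and higher numbers for weaker inhibition:

compound 1 `CCCN(CCC)S(=O)(=O)c1ccc(S(=O)(=O)N2CCC[C@@H](C(=O)OCC)C2)cc1`: 2500 nM
compound 2 `CCN(CC)S(=O)(=O)c1ccc(S(=O)(=O)N2CCC[C@@H](C(=O)NC)C2)cc1`: 13800 nM
compound 3 `CCN(CC)S(=O)(=O)c1ccc(S(=O)(=O)N2CCC[C@@H](C(=O)NC3CN(C(=O)OC(C)(C)C)C3)C2)cc1`: 1800 nM

Compound 1 and compound 3 fall within the scatter of one another in this assay; compound 2 gives a higher number than compound 1, beyond the scatter. Going by the values given here, the single measured step, a 7.7-fold lower number from compound 2 to compound 3 (0.88 log units; beyond the scatter), concerns the amide side of the shared core and so does not bear on the sulfonamide nitrogen substituents.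

Compound 4 `CCCN(CC)S(=O)(=O)c1ccc(S(=O)(=O)N2CCC[C@@H](C(=O)OCC)C2)cc1` differs from compound 1 by hydrogen in place of methyl on a saturated chain carbon, two bonds along the chain from a sulfonamide nitrogen. Among the compounds with values here, no measured step touches this position, so no change beyond the scatter is expected. Compound 4 is estimated at 2500 nM, with a range of 1200 nM to 6000 nM. The expected step of no change at the digits printed from compound 1 to compound 4 (within the scatter) is therefore essentially flat.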

Compound 4, half-maximal inhibitory concentration: 300 nM
Compound 4: the middle estimate sits 8.3-fold (0.92 log units) above what was measured, outside the stated range (below it).
By their numbers in this assay, from the lowest: compound 4; then compounds 3 and 1 (each within the scatter of the next); then compound 2.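

In this assay, the sulfonamide nitrogen substituents are not a silent part of the series: dipropylamino to ethyl(propyl)amino gives an 8.3-fold lower number from compound 1 to compound 4 (0.92 log units; beyond the scatter). The removal of a single methyl, on a saturated chain carbon two bonds along the chain from a sulfonamide nitrogen, is thus enough to move the number on an otherwise unchanged core. Nothing available accounts for this step.

Open, going by these compounds, is whether dibutylamino or a pyrrolidine on that sulfonamide nitrogen would follow or reverse the step. Also open, on these data alone, is whether ethyl(propyl)amino gives a similar step with the amide side of compound 3.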